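Swapping the Furan Amide for a Pyridine Amide

This account rests on a few compounds, and the source may have more. Where it says the series, first, only, none or still open, it means among the compounds named here.

Compound 1 `O=C(Nc1nc(-c2ccccc2)nc2cn(-c3ccccc3)nc12)c1ccco1` gives 24 nM in an assay on CHO cells for displacement of a labelled ligand from adenosine receptor A3 (Homo sapiens), read by scintillation counting, with a stated time of 60 min; on this read-out higher numbers stand for weaker inhibition and lower numbers for stronger inhibition.
Compound 2 `O=C(c1ccco1)N(C(=O)c1ccco1)c1nc(-c2ccccc2)nc2cn(-c3ccccc3)nc12` gives 75 nM in this assay.
Compound 3 `COc1ccc(-n2cc3nc(-c4ccccc4)nc(NC(C)=O)c3n2)cc1` gives 98 nM in this assay.

Of these three, compound 1 has the lowest number and so the strongest inhibition: the step of a 3.1-fold higher number from compound 1 to compound 2 (0.49 log units; beyond the scatter) lies beyond the scatter, and compound 3 sits further out still. Compound 4 `O=C(Nc1nc(-c2ccccc2)nc2cn(-c3ccccc3)nc12)c1ccncc1` differs from compound 1 in one place: pyridin-4-yl in place of furan-2-yl on a carbonyl carbon. Among the measured compounds shown here, no measured pair shows this exchange. For the measured compounds named here, the only single-place step, from compound 1 to compound 2, adds a second carbonyl rather than swapping the ring, and compound 3 differs in more than one place, so neither bears directly on this change. Compound 4 is expected to give 50 nM in this assay, between 15 nM and 200 nM. The expected step is a 2.1-fold higher number from compound 1 to compound 4 (0.32 log units; beyond the scatter), which may still fall within the scatter.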

Compound 4, inhibition constant: 25 nM
Estimate against measurement, compound 4: 2.0-fold (0.30 log units) above, and the stated range covers the measured number.
By their numbers in this assay, from the lowest: compounds 1 and 4 (each within the scatter of the next); then compounds 2 and 3 (each within the scatter of the next).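

In this assay, pyridin-4-yl in place of furan-2-yl on the carbonyl carbon gives a 1.0-fold higher number from compound 1 to compound 4 (0.02 log units; within the scatter), so at this position the six-membered aromatic ring reads the same as the five-membered one. The earlier single-place step changed the amide-type nitrogen, not this ring, so it could not show this. Nothing measured here explains why the two rings match.

On these data alone, how a thiophen-2-yl ring, a cyclohexyl ring or a longer alkyl chain on this carbonyl carbon would read remains open.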